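The source may report more compounds than this note shows. Statements on the series, on what has been measured and on what is new or still open speak of the compounds shown alone.

Among the compounds with values here, both compounds measured so far share one core, an alpha-keto oxazole carrying a seven-carbon chain that ends in a phenyl ring, and differ only in the group attached to the oxazole. Compound 1 `O=C(CCCCCCc1ccccc1)c1ncc(-c2ccc(CCl)cn2)o1` gives 22.4 nM in an assay for inhibition of Fatty-acid amide hydrolase 1 (Rattus norvegicus), using a Dixon plot (a lower number here means a stronger inhibitor, a higher number a weaker inhibitor), the higher of the two numbers recorded, so it is the weaker of the pair. Compound 2 `C[S+]([O-])/C=C/c1ccc(-c2cnc(C(=O)CCCCCCc3ccccc3)o2)nc1` gives 3 nM in this assay. The change between them, a 7.5-fold lower number from compound 1 to compound 2 (0.87 log units; beyond the scatter), swapped one small substituent on the pyridine ring for another and left the ring itself in place.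

Compound 3 `COCOCCCCCc1cnc(C(=O)CCCCCCc2ccccc2)o1` goes further. Here (a group of 9 heavy atoms (7 carbon, 2 oxygen; no ring) in place of a group of 8 heavy atoms (6 carbon, 1 nitrogen, 1 chlorine; one six-membered aromatic ring with 1 hetero atom), on an aromatic carbon), so the whole pyridine ring leaves and an open chain enters at the same position on the oxazole. Within the data shown here, no measured step describes the removal of the ring; the one step known only reshaped a substituent on it. With the ring gone, a weakening is the more likely outcome, and the step of a 5.4-fold higher number from compound 1 to compound 3 (0.73 log units; beyond the scatter) is expected. The estimate for compound 3 in this assay is 120 nM, with a plausible range from 20 nM to 700 nM.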

Compound 3, inhibition constant: 24.1 nM
Compound 3: the middle estimate sits 5.0-fold (0.70 log units) above what was measured, within the range that was stated.
By their numbers in this assay, from the lowest: compound 2; then compounds 1 and 3 (each within the scatter of the next).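

The open chain of compound 3 takes the place of the whole six-membered aromatic ring with 1 hetero atom, yet in this assay the result is a 1.1-fold higher number from compound 1 to compound 3 (0.03 log units; within the scatter). So, for this pair, an aromatic ring on this aromatic carbon next to the ring oxygen is not needed to keep the number where compound 1 has it, and a group with no ring, with 9 heavy atoms in place of 8, serves equally well. This sets the step apart from a 7.5-fold lower number from compound 1 to compound 2 (0.87 log units; beyond the scatter), where the ring stayed and only its substituent differed: a small edit there moved the number beyond the scatter, while this far larger edit did not, although no information is available on what lies behind this result.

The compounds shown leave open whether the two oxygens of the open chain matter, or whether a plain alkyl chain of similar length, a much shorter chain, or a chain ending in an amine or a carboxylic acid would give a similar number. They also leave open whether a substituent on an open chain can shift the number as far as the one on the ring did.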